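A few compounds are considered here, and "the series" means these few. Any claim that something is new, unique, unknown or untested is made for them only; others in the source may bear on it.

Measured in a functional assay on KYSE-450 cells (Homo sapiens) for inhibition, read by MTT assay, with a stated time of 48 h; a higher number here means a weaker inhibitor, a lower number a stronger inhibitor:
- compound 1 `C/C=C/C(=O)N(Cc1ccc(OC)c([N+](=O)[O-])c1)c1cc(OC)c(OC)c(OC)c1`: 510 nM
- compound 2 `C/C=C/C(=O)N(Cc1ccc(OC)c(OC)c1)c1cc(OC)c(OC)c(OC)c1`: 39100 nM
- compound 3 `C/C=C/C(=O)N(Cc1cccc(O)c1)c1cc(OC)c(OC)c(OC)c1`: 14700 nM

Compound 3 has the second highest of the three numbers, so it is a weak member of this small set. Its value lies closer to that of compound 2 than to that of compound 1, and both gaps are beyond the scatter.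

The next compound is compound 4 `C/C=C/C(=O)N(Cc1ccc(OC)c(Cl)c1)c1cc(OC)c(OC)c(OC)c1`. The change is 3-chloro-4-methoxyphenyl in place of 3-hydroxyphenyl on a saturated chain carbon bound to an amide-type nitrogen.

Within the data shown here, no measured step covers this exchange directly. Among the measured compounds shown here, the closest evidence is the single measured step, a 77-fold higher number from compound 1 to compound 2 (1.88 log units; beyond the scatter), which is large and beyond the scatter. That step is methoxy in place of nitro on an aromatic carbon, and compound 4 carries chlorine on that same carbon. For the measured compounds named here, no compound with chlorine there has been measured, so the large span of that step sets only loose bounds.

A value inside that span is expected, nearer its upper part, which would make a moderate move to a lower number in this assay beyond the scatter. The step expected is a 4.9-fold lower number from compound 3 to compound 4 (0.69 log units; beyond the scatter). The estimate for compound 4 is 3000 nM, with an expected range of 600 nM to 15000 nM.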

Compound 4, half-maximal inhibitory concentration: 10100 nM
Beside the measured number, compound 4's estimate is 3.4-fold (0.53 log units) below it; measured number inside the range.
By their numbers in this assay, from the lowest: compound 1; then compounds 4 and 3 (each within the scatter of the next); then compound 2.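

Chlorine on the aromatic carbon that holds nitro in compound 1 gives only a partial recovery in this assay: chloro in place of methoxy yields a modest gain (a 3.9-fold lower number from compound 2 to compound 4 (0.59 log units; beyond the scatter)), whereas chloro in place of nitro gives a large loss (a 20-fold higher number from compound 1 to compound 4 (1.30 log units; beyond the scatter)). Among the three groups seen on this carbon, the low number therefore belongs to nitro alone, and the change from methoxy to chloro does not come close to reproducing it. The exchange of 3-hydroxyphenyl for 3-chloro-4-methoxyphenyl on a saturated chain carbon bound to an amide-type nitrogen (a 1.5-fold lower number from compound 3 to compound 4 (0.16 log units; within the scatter)) stays within the scatter, so these two differently substituted rings cannot be told apart in this assay, and a hydroxy group without a methoxy group gives no separate reading from chloro with one.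

No measurement on hand gives a reason for the standing of nitro on this carbon. Going by these compounds, whether that standing is particular to nitro stays open, and a nitrile, a trifluoromethyl group or an amine on the same carbon, with the rest of the core of compound 1 unchanged, would address that question.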